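A few compounds are considered here, and "the series" means these few. Any claim that something is new, unique, unknown or untested is made for them only; others in the source may bear on it.

Of the compounds shown here, three have been measured in a functional assay on MGC-803 cells (Homo sapiens) for inhibition, read by MTT assay, with a stated time of 72 h; a higher number here means a weaker inhibitor, a lower number a stronger inhibitor. Compound 1 `O=C(CSc1nc(Nc2ccccc2)c2ccccc2n1)Nc1ccccc1Br` gives 18600 nM. Compound 2 `O=C(CSc1nc(Nc2ccccc2)c2ccccc2n1)Nc1cccc([N+](=O)[O-])c1` gives 28100 nM; the step of a 1.5-fold higher number from compound 1 to compound 2 (0.18 log units; within the scatter) lies within the scatter. Compound 3 `C=CC(=O)Nc1cccc(NC(=O)CSc2nc(Nc3cccc(F)c3)c3ccccc3n2)c1` gives 6250 nM, the lowest of the three numbers; compound 1 stands nearest, with a higher number beyond the scatter, and compound 2 furthest, also beyond the scatter.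

Compound 4 `C=CC(=O)Nc1cccc(NC(=O)CSc2nc(Nc3ccc(F)c(Cl)c3)c3ccccc3n2)c1` is not yet measured in this assay. It differs from compound 3 in one place: 3-chloro-4-fluorophenyl in place of 3-fluorophenyl on a nitrogen on an aromatic ring. Among the compounds with values here, the only measured step, from compound 1 to compound 2, changes the group on the amide-type nitrogen, not the group on the nitrogen on an aromatic ring, so no measured step bears on this change. The change adds one chlorine to the 3-fluorophenyl while keeping the fluorine, and nothing in the series shows what that does. A step beyond the scatter is therefore not expected in this assay in either direction; the estimated step is a 1.0-fold lower number from compound 3 to compound 4 (0.02 log units; within the scatter). Compound 4 is expected to give 6000 nM, with a range from 2500 nM to 15000 nM.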

Compound 4, half-maximal inhibitory concentration: 7850 nM
Compound 4: the middle estimate sits 1.3-fold (0.12 log units) below what was measured, within the range that was stated.
By their numbers in this assay, from the lowest: compounds 3 and 4 (each within the scatter of the next); then compounds 1 and 2 (each within the scatter of the next).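

In this assay, within the data shown here, the only measured step at this place, on a nitrogen on an aromatic ring, is a 1.3-fold higher number from compound 3 to compound 4 (0.10 log units; within the scatter). For this one pair, 3-chloro-4-fluorophenyl with 8 heavy atoms and 3-fluorophenyl with 7 read alike, so the added chlorine with the fluorine retained produces no step beyond the scatter. No available measurement accounts for this result.

The compounds shown leave open whether a different substituent on this phenyl, such as an amine or a carboxylic acid, or a longer chain in place of the ring on this nitrogen, would give a step beyond the scatter. Going by these compounds, compound 1 and compound 2 each differ from compound 3 in more than one place, so the part of the structure behind the gaps between their printed values also remains open.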